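A few compounds are considered here, and "the series" means these few. Any claim that something is new, unique, unknown or untested is made for them only; others in the source may bear on it.

In a functional assay on HepG2 cells (Homo sapiens) for inhibition, read by MTT assay, with a stated time of 48 h (on this read-out higher numbers stand for weaker inhibition of growth and lower numbers for stronger inhibition of growth), compound 1 (`COc1ccc(C(=O)N2N=C(c3ccccc3)CC2c2cn(C)c3ccccc23)cn1`) gives 3130 nM and compound 2 (`Cn1cc(C2CC(c3ccc(Cl)cc3)=NN2C(=O)c2cccnc2)c2cc(Br)ccc21`) gives 5800 nM as its value. These two numbers lie within the usual scatter of repeated measurements, so compound 2 stands level with compound 1 and neither can be ranked over the other.

Compound 3 (`COc1cc(C2=NN(C(=O)c3cccnc3)C(c3cn(C)c4ccc(Br)cc34)C2)cc(OC)c1OC`) keeps compound 2 except at one place, where it has 3,4,5-trimethoxyphenyl in place of 4-chlorophenyl on a carbon with a double bond to nitrogen. Going by the values given here, no measured pair of compounds differs in just one place, so nothing yet shows what a single change does in this assay and any forecast is uncertain.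

The expectation starts from compound 2 at 5800 nM as its anchor and allows a small move toward a lower number, meaning stronger inhibition of growth, of about the size of the scatter. The estimated step is a 1.9-fold lower number from compound 2 to compound 3 (0.29 log units; within the scatter) in this forecast. For compound 3 the expected value is 3000 nM with an estimated range from 800 nM to 11000 nM for a repeat measurement.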

Compound 3, concentration for 50% growth inhibition: > 10000 nM
Compound 3 gave a limit, no number (the forecaster's own chance of this, stated with the estimate: 5%); middle value at least 3.3-fold (0.52 log units) away from the limit.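

In this assay, going by these compounds alone, 3,4,5-trimethoxyphenyl in place of 4-chlorophenyl on a carbon with a double bond to nitrogen gives an at least 1.7-fold higher number from compound 2 to compound 3 (0.23 log units; that floor lies within the scatter), and this is the first step in the set that isolates a single change to the shared core. Compound 3 gave a limit of the assay and not a number: the limit of > 10000 nM in this assay, at which 1 of the 3 values shown sits. Going by these compounds, the step therefore shows that this swap at this position brought no measurable gain in inhibition of growth, but its true size remains unknown, and because its floor lies within the scatter, it does not by itself establish a real loss.

One swap cannot separate the removal of the chlorine from the arrival of the three methoxy groups, so a phenyl group with no substituent, a 4-methoxyphenyl group or a 4-fluorophenyl group at the same position would be needed to tell these apart. On these data alone, it also remains open how this position would respond to a group of another kind, such as a 4-aminophenyl group or a short alkyl chain in place of the aromatic ring.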